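Swapping chloro for iodo on compound 3

This account rests on a few compounds, and the source may have more. Where it says the series, first, only, none or still open, it means among the compounds named here.

In a functional assay on MCF7 cells (Homo sapiens) for antiproliferative activity, read by sulforhodamine B assay, with a stated time of 48 h (on this read-out higher numbers stand for weaker inhibition and lower numbers for stronger inhibition), compound 1 `Cc1ccccc1OS(=O)(=O)c1ccc(N2CCN(C)C2=O)cc1` gives 5600 nM and compound 2 `COc1cccc(OS(=O)(=O)c2ccc(N3CCN(C)C3=O)cc2)c1` gives 3000 nM while compound 3 `CN1CCN(c2ccc(S(=O)(=O)Oc3cccc(Cl)c3)cc2)C1=O` gives 2200 nM on the same read-out. The gaps around that last value are a 2.5-fold lower number from compound 1 to compound 3 (0.41 log units; beyond the scatter) on one side and a 1.4-fold lower number from compound 2 to compound 3 (0.13 log units; within the scatter) on the other. This second step, chloro in place of methoxy, is the closest measured guide. Compound 4 `CN1CCN(c2ccc(S(=O)(=O)Oc3cccc(I)c3)cc2)C1=O` differs by iodo in place of chloro on an aromatic carbon with iodo in place of chloro on an aromatic carbon, meta to a large group. Among the compounds with values here, no iodo compound has been measured. The expected step is a 1.1-fold lower number from compound 3 to compound 4 (0.04 log units; within the scatter) and it is not expected to exceed the scatter. In this assay compound 4 is estimated at 2000 nM (expected range 900 nM to 4500 nM).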

Compound 4, half-maximal inhibitory concentration: 560 nM
Compound 4: middle estimate off by 3.6-fold (0.55 log units), on the high side; measured number outside the range, below it.
By their numbers in this assay, from the lowest: compound 4; then compounds 3, 2 and 1 (each within the scatter of the next, the first and the last beyond it).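

In this assay, the choice of halogen at this position matters: iodo in place of chloro gives a step beyond the scatter (a 3.9-fold lower number from compound 3 to compound 4 (0.59 log units; beyond the scatter)), whereas the earlier change from methoxy to chloro stayed within it. Iodo also stands clearly apart from methoxy (a 5.4-fold lower number from compound 2 to compound 4 (0.73 log units; beyond the scatter)), and 3-iodophenyl in place of 2-methylphenyl gives the widest step in the set (a 10-fold lower number from compound 1 to compound 4 (1.00 log units; beyond the scatter)). No measurement shown here explains why iodo differs from chloro. Going by these compounds, how bromo, trifluoromethyl or an amine would behave at this position remains open, as does whether iodo would give a similar step elsewhere on the ring.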